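Ring swap on the thiocarbonyl carbon: compound 1 to compound 3

This account rests on a few compounds, and the source may have more. Where it says the series, first, only, none or still open, it means among the compounds named here.

Compound 1 `CC1CCN(C(=S)SCc2ccc(C(=O)Nc3ccccc3N)cc2)CC1` carries a 4-methylpiperidin-1-yl on the thiocarbonyl carbon. In a functional assay on HeLa cells (Homo sapiens) for antiproliferative activity, read by CCK-8 assay, with a stated time of 72 h, tested at 2 uM (a higher number here means a stronger effect of the compound at the concentration tested, a lower number a weaker effect), compound 1 gives 46.8%, the lowest of the two numbers in hand. The nearest is compound 2 `Nc1ccccc1NC(=O)c1ccc(CSC(=S)N2CCN(c3cccnc3)CC2)cc1`, which in this assay gives 66.2%; the gap between compound 1 and compound 2 lies beyond the scatter. Among the compounds with values here, no step between measured compounds that differ in one place has been derived, so of this pair only the two values themselves can be said.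

Compound 3 `Nc1ccccc1NC(=O)c1ccc(CSC(=S)N2CCCC2)cc1` has not yet been measured in this assay. It differs from compound 1 in one place: pyrrolidin-1-yl in place of 4-methylpiperidin-1-yl on a thiocarbonyl carbon. Within the data shown here, no measured pair isolates this change, and compound 2 differs from compound 1 in another way, so the size of the step is open. For compound 3 the step of a number 1.8 percentage points lower from compound 1 to compound 3 (within the scatter) is expected to be small, not beyond the scatter, in either direction. Compound 3 is therefore estimated at 45%, with a range from 25% to 65%.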

Compound 3, a percentage reported as inhibition, at one concentration (the size of the read-out at that concentration, not a potency): 51.3%
The estimate for compound 3 lay 6.3 percentage points below the measured number; low and high end bracket the measured number.
By their numbers in this assay, from the lowest: compounds 1 and 3 (each within the scatter of the next); then compound 2.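

In this assay, within the data shown here, the step of a number 4.5 percentage points higher from compound 1 to compound 3 (within the scatter) is the first measured step that isolates the group on the thiocarbonyl carbon, here pyrrolidin-1-yl in place of 4-methylpiperidin-1-yl. At this position, a five-membered and a six-membered non-aromatic ring, each with 1 hetero atom, cannot be told apart by this read-out at the one concentration tested, and the methyl-bearing ring shows no measurable advantage or drawback against the smaller ring without a methyl. No measured property of these compounds bears on this result, so the outcome remains a description without an explanation.

Still open, as far as these compounds go, is how morpholin-4-yl, or an open-chain group such as diethylamino, would read on the same thiocarbonyl carbon in this assay, and so whether the insensitivity seen here extends beyond these two rings. From the compounds shown here alone, the read-out also comes from one concentration, so it remains open whether compound 1 and compound 3 would stay this close on a measure of potency.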